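A few compounds are considered here, and "the series" means these few. Any claim that something is new, unique, unknown or untested is made for them only; others in the source may bear on it.

Measured compounds in a functional assay on HCT-15 cells (Homo sapiens) for cytotoxicity, read by MTT assay, with a stated time of 72 h; a lower number here means a stronger inhibitor, a higher number a weaker inhibitor:
compound 1, `O=C1C(Nc2ccc(F)cc2)=CC(=O)c2ncncc21`, gives 0.02 ug/mL
compound 2, `O=C1C(Nc2ccc(I)cc2)=CC(=O)c2ncncc21`, gives 0.01 ug/mL

Compound 2 has the lowest of the two numbers in this assay, and its nearest neighbour is compound 1, which gives a number only a 2.0-fold lower number from compound 1 to compound 2 (0.30 log units; within the scatter) away from it; the two therefore cannot be ranked against each other on this evidence.

Compound 3, `Cc1ccc(NC2=CC(=O)c3ncncc3C2=O)cc1`, differs from compound 2 in one place: methyl in place of iodo on an aromatic carbon. The group sits para to a large group on a six-membered aromatic ring of carbon only.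

For the measured compounds named here, only one measured step bears on this change, that from compound 1 to compound 2, in which the same position carried fluoro and then iodo: a 2.0-fold lower number from compound 1 to compound 2 (0.30 log units; within the scatter), which stays within the scatter. The shared core was untouched in that step and is untouched again here. With a single comparison of this kind, both within the scatter, he expects for compound 3 no step beyond the scatter in this assay, and his estimated step is a 2.0-fold higher number from compound 2 to compound 3 (0.30 log units; within the scatter). His estimate for compound 3 in this assay is 0.02 ug/mL, within a range from 0.005 ug/mL to 0.08 ug/mL.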

Compound 3, half-maximal inhibitory concentration: 0.01 ug/mL
Compound 3: middle estimate off by 2.0-fold (0.30 log units), on the high side; the measured number falls inside the stated range.
By their numbers in this assay, from the lowest: compounds 2, 3 and 1 (each within the scatter of the next).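

In this assay the position para to a large group has now carried a methyl as well as two halogens, and the methyl reads the same as both: replacing iodo gives (no change at the digits printed from compound 2 to compound 3 (within the scatter)), and replacing fluoro gives (a 2.0-fold lower number from compound 1 to compound 3 (0.30 log units; within the scatter)). The earlier pair could speak only to an exchange of one halogen for another, whereas these steps extend the finding to a group built on carbon, and all three compounds stand within the scatter of one another, so none can be ranked above the others on this evidence. No measurement shown here explains why these three groups read alike.

For the compounds shown here, it remains open whether an amine, a carboxylic acid or a longer chain such as butyl on the same aromatic carbon would also stay within the scatter in this assay or would give the first step beyond it. The three compounds also share one core, so they leave open how far this tolerance of exchange at the position would carry over to a different core or to other cell lines.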